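A few compounds are considered here, and "the series" means these few. Any claim that something is new, unique, unknown or untested is made for them only; others in the source may bear on it.

Compound 1 `O=C(/C=C/c1ccccc1)c1cccc(NC(=O)c2cc(-c3ccncc3)n[nH]2)c1`: 71500 nM
Compound 2 `O=C(/C=C/c1cccc2ccccc12)c1cccc(NC(=O)c2cc(-c3ccncc3)n[nH]2)c1`: 72100 nM

In a functional assay, read by spectrophotometry, tested at 100 uM (on this read-out lower numbers stand for stronger inhibition and higher numbers for weaker inhibition), compound 2 holds the higher of the two numbers, but compound 1 lies within the scatter of it, so neither can be called the weaker inhibitor. Among the compounds with values here, the single measured step, a 1.0-fold higher number from compound 1 to compound 2 (0.00 log units; within the scatter), shows that exchanging phenyl for naphthalen-1-yl on the double-bonded chain carbon left the read-out unchanged. Compound 3 `Cc1ccc(/C=C/C(=O)c2cccc(NC(=O)c3cc(-c4ccncc4)n[nH]3)c2)cc1` differs from compound 2 by 4-methylphenyl in place of naphthalen-1-yl on a double-bonded chain carbon bound to a double-bonded chain carbon. Within the data shown here, the step of a 1.0-fold lower number from compound 2 to compound 3 (0.01 log units; within the scatter) is expected to stay within the scatter because the only comparable step a 1.0-fold higher number from compound 1 to compound 2 (0.00 log units; within the scatter) did. Compound 3 is therefore estimated at 70000 nM, in a range from 35000 nM to 140000 nM.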

Compound 3, half-maximal inhibitory concentration: 64600 nM
Estimate against measurement, compound 3: 1.1-fold (0.03 log units) above, and the stated range covers the measured number.
By their numbers in this assay, from the lowest: compounds 3, 1 and 2 (each within the scatter of the next).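

In this assay, both a 1.1-fold lower number from compound 2 to compound 3 (0.05 log units; within the scatter) and a 1.1-fold lower number from compound 1 to compound 3 (0.04 log units; within the scatter) stay within the scatter. Adding a methyl in place of hydrogen on an aromatic carbon therefore does not separate these compounds, and neither does the change from two aromatic rings in naphthalen-1-yl to one in 4-methylphenyl. Nothing available explains why these groups read alike. From the compounds shown here alone, whether an amine or a carboxylic acid on that aromatic ring would move the number beyond the scatter remains open.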